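Replacing a Carbamate Tail with a Hydroxyl Chain

The source may report more compounds than this note shows. Statements on the series, on what has been measured and on what is new or still open speak of the compounds shown alone.

Of the compounds shown here, three sharing one core have been measured in an assay on HEK293 cells for displacement of a labelled ligand from NPC1-like intracellular cholesterol transporter 1 (Homo sapiens); on this read-out higher numbers stand for weaker inhibition and lower numbers for stronger inhibition. Compound 1 `CCOC(=O)C1CCN(C(=O)CN2CN(c3ccccc3)C3(CCN(C(=O)c4ccc(C5CCCCC5)cc4)CC3)C2=O)CC1` gives 900 nM, compound 3 `CCC1CCCN(C(=O)CN2CN(c3ccccc3)C3(CCN(C(=O)c4ccc(C5CCCCC5)cc4)CC3)C2=O)C1` gives 2600 nM, and compound 2 `CC(C)(C)OC(=O)NCCCNC(=O)CN1CN(c2ccccc2)C2(CCN(C(=O)c3ccc(C(C)(C)C)cc3)CC2)C1=O` gives 4500 nM; compound 3 lies within the scatter of compound 2, whereas compound 1 stands clearly lower. Going by the values given here, the only measured step, a 2.9-fold higher number from compound 1 to compound 3 (0.46 log units; beyond the scatter), concerns the group on the carbonyl carbon, not the chain end.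

Compound 4 `CC(C)(C)c1ccc(C(=O)N2CCC3(CC2)C(=O)N(CC(=O)NCCCCCO)CN3c2ccccc2)cc1` differs from compound 2 at that chain end: 2-hydroxyethyl in place of (tert-butoxycarbonyl)amino on a saturated chain carbon, three bonds along the chain from an amide-type nitrogen. Among the compounds with values here, no measured step touches this position, so the data give no direction for this assay. Compound 4 is therefore expected to show a step of a 1.1-fold lower number from compound 2 to compound 4 (0.05 log units; within the scatter), within the scatter. In this assay compound 4 is estimated at 4000 nM, between 1500 nM and 12000 nM.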

Compound 4, half-maximal inhibitory concentration: 9400 nM
For compound 4 the middle estimate is 2.4-fold (0.37 log units) below the measured one; low and high end bracket the measured number.
By their numbers in this assay, from the lowest: compound 1; then compounds 3 and 2 (each within the scatter of the next); then compound 4.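

Going by these compounds alone, at this chain end, which no earlier step touched, the change now has a direction in this assay: 2-hydroxyethyl in place of (tert-butoxycarbonyl)amino gives a 2.1-fold higher number from compound 2 to compound 4 (0.32 log units; beyond the scatter), a modest move towards weaker inhibition. The carbamate end therefore cannot be exchanged for the hydroxyl chain without a loss beyond the scatter. No measured evidence accounts for this step. Still open, from the compounds shown here alone, is how a primary amine or a carboxylic acid at the same chain end would compare with compound 2 and compound 4, and whether a shorter hydroxyl chain would recover the loss.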